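The source may report more compounds than this note shows. Statements on the series, on what has been measured and on what is new or still open speak of the compounds shown alone.

In an ADME assay on HEL cells (Homo sapiens) for cytotoxicity, with a stated time of 3 days (a lower number here means that less compound is tolerated, a higher number that more compound is tolerated), three closely related compounds have been measured. Compound 1 `Cc1cn([C@@H]2O[C@H](CO)[C@@]3(OS(=O)(=O)C=C3NC(=O)NC(=O)c3ccccc3)[C@H]2O[Si](C)(C)C(C)(C)C)c(=O)n(C)c1=O` gives 20000 nM. Compound 2 `Cc1cn([C@@H]2O[C@H](CO)[C@@]3(OS(=O)(=O)C=C3NC(=O)NC(=O)c3ccccc3)[C@H]2O)c(=O)n(C)c1=O` gives 100000 nM. For compound 3 `Cc1cn([C@@H]2O[C@H](COC(=O)c3ccccc3)[C@@]3(OS(=O)(=O)C=C3NC(=O)NC(=O)c3ccccc3)[C@H]2O)c(=O)n(C)c1=O` the result is only a limit of the assay, > 100000 nM, and not a number.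

Two measured steps connect them. The change from compound 2 to compound 1 is a group of 7 heavy atoms (6 carbon, 1 silicon; no ring) in place of a hydrogen atom, on an oxygen on a saturated carbon; it gave a 5.0-fold lower number from compound 2 to compound 1 (0.70 log units; beyond the scatter). The change from compound 2 to compound 3 is benzoyl in place of hydrogen on an oxygen on a saturated carbon; it gave a number no lower from compound 2 to compound 3 (the limit leaves the size open), which rests on (the limit of > 100000 nM in this assay, at which 1 of the 3 values shown sits).

Compound 4 `Cc1cn([C@@H]2O[C@H](COC(=O)c3ccccc3)[C@@]3(OS(=O)(=O)C=C3NC(=O)NC(=O)c3ccccc3)[C@H]2O[Si](C)(C)C(C)(C)C)c(=O)n(C)c1=O` has not yet been measured in this assay. It differs from compound 3 by a group of 7 heavy atoms (6 carbon, 1 silicon; no ring) in place of a hydrogen atom, on an oxygen on a saturated carbon. This is the same change that was made from compound 2 to compound 1, and the surroundings of the place are described in the same words, so the same kind of step may be expected. The two cores, that of compound 3 and that of compound 2, differ by benzoyl in place of hydrogen on an oxygen on a saturated carbon.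

Because the earlier step gave a 5.0-fold lower number from compound 2 to compound 1 (0.70 log units; beyond the scatter), a step of a similar size, an at least 3.3-fold lower number from compound 3 to compound 4 (0.52 log units; beyond the scatter), is expected from compound 3 to compound 4. Since compound 3 sits at a limit, the starting point is open, so the expectation is wide. For compound 4 the estimated result in this assay is 30000 nM, somewhere between 10000 nM and 100000 nM.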

Compound 4, minimum cytotoxic concentration: >= 5000 nM
Compound 4 gave a limit, no number; the forecaster's own chance of this, stated with the estimate: 30%; the middle value is on the limit's open side.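

In this assay compound 4 gives only a limit of the assay, >= 5000 nM, and not a number. The steps to it from compound 3, itself at a limit, and from compound 1 cannot be read. The compounds shown leave open whether the group of 7 heavy atoms, placed on a compound carrying benzoyl, repeats the earlier change: a 5.0-fold lower number from compound 2 to compound 1 (0.70 log units; beyond the scatter).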